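From 3-methylbut-2-en-1-yl to 2-fluorobenzyl: an expected reading

A few compounds are considered here, and "the series" means these few. Any claim that something is new, unique, unknown or untested is made for them only; others in the source may bear on it.

compound 1 `CC(C)=CCn1c(CN2CCN(C(=O)C3CC3)CC2)nc2ccccc21` — 74.3%
compound 2 `Cc1cccc(Cn2c(CN3CCN(C(=O)C4CCCC4)CC3)nc3ccccc32)c1` — 67.5%

In an assay on isolated protein for inhibition of aldehyde dehydrogenase 1A1 (Homo sapiens), read by spectrophotometry, tested at 10 uM (a higher number here means more inhibition at the concentration tested (going by the name of the read-out), a lower number less inhibition), compound 1 gives 74.3%, the higher of the two readings, while compound 2 gives 67.5%; the gap lies within the usual scatter, so no order between them can be claimed. Compound 3 `O=C(C1CC1)N1CCN(Cc2nc3ccccc3n2Cc2ccccc2F)CC1` differs from compound 1 by 2-fluorophenyl in place of 2-methylprop-1-en-1-yl on a saturated chain carbon bound to an aromatic nitrogen. For the measured compounds named here, no measured pair shows this change, so the expected step of a number 6.3 percentage points lower from compound 1 to compound 3 (within the scatter) is small, in either direction, with nothing clearly beyond the scatter. Compound 3 is therefore expected to read 68%, with a range from 45% to 88%.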

Compound 3, a percentage reported as inhibition, at one concentration (the size of the read-out at that concentration, not a potency): 40.7%
Compound 3: middle estimate off by 27.3 percentage points, on the high side, and the stated range ends above it.
By their numbers in this assay, from the lowest: compound 3; then compounds 2 and 1 (each within the scatter of the next).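

At the saturated chain carbon bound to an aromatic nitrogen, 2-fluorophenyl in place of 2-methylprop-1-en-1-yl is not a neutral change: this assay shows a number 33.6 percentage points lower from compound 1 to compound 3 (beyond the scatter) and this step lies beyond the scatter. For the compounds shown here, it is the first reading of a change at this position alone, as compound 1 and compound 2 differ in more than one place. Nothing measured here explains the step.

Whether the fluorine or the ring accounts for the step remains open. So does what a plain benzyl group or a longer alkyl chain would read at this position.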